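This account rests on a few compounds, and the source may have more. Where it says the series, first, only, none or still open, it means among the compounds named here.

Measured compounds in a functional assay on HL-60 cells (Homo sapiens) for antiproliferative activity, read by MTT assay, with a stated time of 48 h; a lower number here means a stronger inhibitor, a higher number a weaker inhibitor:
- compound 1 `CN(C)CCCn1c(N)c(-c2nc3ccccc3[nH]2)c2nc(C#N)c(C#N)nc21`: 870 nM
- compound 2 `CCN(CC)CCCn1c(N)c(-c2nc3ccccc3[nH]2)c2nc(C#N)c(C#N)nc21`: > 730 nM
- compound 3 `CN(C)CCCn1c(N)c(-c2nc3cc(Cl)ccc3[nH]2)c2nc(C#N)c(C#N)nc21`: 2930 nM

The value of compound 2 in this assay is a limit of the assay, not a number; the same limit is noted as the limit of > 730 nM in this assay, at which 1 of the 3 values shown sits. Compound 3 carries the change chloro in place of hydrogen on an aromatic carbon relative to compound 1 and gives the higher number, a 3.4-fold higher number from compound 1 to compound 3 (0.53 log units; beyond the scatter), a step that lies beyond the scatter. Compound 2 carries the change diethylamino in place of dimethylamino on a saturated chain carbon, three bonds along the chain from an aromatic nitrogen relative to compound 1, and the resulting step, a step that the limit leaves unreadable from compound 1 to compound 2, cannot be read in size since one end of it is a limit.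

Compound 4 `CCN(CC)CCCn1c(N)c(-c2nc3cc(Cl)ccc3[nH]2)c2nc(C#N)c(C#N)nc21` is not yet measured. It stands to compound 3 as compound 2 stands to compound 1: the change diethylamino in place of dimethylamino on a saturated chain carbon, three bonds along the chain from an aromatic nitrogen is the same kind of change, placed on the same saturated chain carbon, while the two cores differ by the chloro in place of hydrogen described under (chloro in place of hydrogen on an aromatic carbon). Among the measured compounds shown here, the only precedent for this change, from compound 1 to compound 2, is unreadable because of the limit of > 730 nM in this assay, at which 1 of the 3 values shown sits, so no measured size can be carried over. With compound 3 at 2930 nM as the starting point, the step from compound 3 to compound 4 is expected to be small, a 1.2-fold higher number from compound 3 to compound 4 (0.08 log units; within the scatter), with wide uncertainty in both directions. The estimate for compound 4 in this assay is therefore 3500 nM, expected to fall between 1400 nM and 9000 nM.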

Compound 4, half-maximal inhibitory concentration: 3470 nM
Estimate against measurement, compound 4: 1.0-fold (0.00 log units) above; the range from low to high includes it.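

In this assay, diethylamino in place of dimethylamino on the chloro-bearing core gives a 1.2-fold higher number from compound 3 to compound 4 (0.07 log units; within the scatter), so on this core the two amines read alike within the scatter. Compound 2 gives > 730 nM, which is a limit of the assay and not a number. The steps that touch compound 2 cannot be read, so this one pair shows the change on a single core and does not show whether it carries over to the core of compound 1, because the only other pair with this change ends at a limit: the limit of > 730 nM in this assay, at which 1 of the 4 values shown sits.

Going by these compounds, the chloro change has one readable step, a 3.4-fold higher number from compound 1 to compound 3 (0.53 log units; beyond the scatter), and whether it holds with diethylamino on the chain stays open. Also open, on these data alone, is how this assay would read for a ring amine such as piperidine or morpholine in place of diethylamino, for a longer chain than 3-(dimethylamino)propyl, or for fluoro or methoxy in place of chloro on the same aromatic carbon.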